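This account rests on a few compounds, and the source may have more. Where it says the series, first, only, none or still open, it means among the compounds named here.

Within the data shown here, in a functional assay on RS4-11 cells (Homo sapiens) for inhibition, read by CCK-8 assay, with a stated time of 72 h (a higher number here means a weaker inhibitor, a lower number a stronger inhibitor), only two compounds have numbers so far. Compound 1 `CCN(CC)CCCNc1ccc(S(=O)(=O)NC(=O)c2ccc(N3CCN(CC4=C(c5ccc(C(F)(F)F)cc5)CC(C)(C)CC4)CC3)cc2Oc2cnc3[nH]ccc3c2)cc1[N+](=O)[O-]` gives 3 nM, and compound 2 `CC1(C)CCC(CN2CCN(c3ccc(C(=O)NS(=O)(=O)c4ccc(OCC5CCSCC5)c([N+](=O)[O-])c4)c(Oc4cnc5[nH]ccc5c4)c3)CC2)=C(c2ccc(C(F)(F)F)cc2)C1` gives 15 nM, the higher number of the two and so the weaker inhibitor. Compound 3 `CC(Oc1ccc(S(=O)(=O)NC(=O)c2ccc(N3CCN(CC4=C(c5ccc(C(F)(F)F)cc5)CC(C)(C)CC4)CC3)cc2Oc2cnc3[nH]ccc3c2)cc1[N+](=O)[O-])C1CCOCC1` has not been measured. It differs from compound 2 in one group: 1-(oxan-4-yl)ethyl in place of (thian-4-yl)methyl on an oxygen on an aromatic ring. In words, this is 1-(oxan-4-yl)ethyl in place of (thian-4-yl)methyl on an oxygen on an aromatic ring. Among the measured compounds shown here, only one measured step offers guidance, a 5.0-fold higher number from compound 1 to compound 2 (0.70 log units; beyond the scatter), and that step exchanged a group with no ring for one with a six-membered non-aromatic ring. The step to compound 3 keeps such a ring, so a smaller change is expected, with none beyond the scatter in this assay and no clear direction. The estimated change is a 1.1-fold lower number from compound 2 to compound 3 (0.03 log units; within the scatter). For compound 3 the expected value is 14 nM, with an estimated range of 5 nM to 45 nM.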

Compound 3, half-maximal inhibitory concentration: 269 nM
Compound 3: middle estimate off by 19-fold (1.28 log units), on the low side; the whole stated range lies below it.
By their numbers in this assay, from the lowest: compound 1; then compound 2; then compound 3.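

In this assay, among these compounds, the group on this oxygen on an aromatic ring matters far more than the earlier compounds could show. The exchange of (thian-4-yl)methyl for 1-(oxan-4-yl)ethyl gives an 18-fold higher number from compound 2 to compound 3 (1.25 log units; beyond the scatter) even though both groups hold one six-membered non-aromatic ring with 1 hetero atom, so keeping such a ring does not by itself keep the activity. The gap to the open-chain group also widens to a 90-fold higher number from compound 1 to compound 3 (1.95 log units; beyond the scatter) and nothing available explains either step.

The exchange alters two things at once, the ring sulfur to oxygen and the plain methyl link to a branched ethyl link, so the compounds shown leave open which one accounts for the loss, and (oxan-4-yl)methyl on the same oxygen would separate them. Also open, from the compounds shown here alone, is how a ring carrying an amine, such as (piperidin-4-yl)methyl, would fare there.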